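Compound 3 trades its chlorophenyl for a cyanophenyl

The compounds below may be only part of what the source reports. "The series", "measured", "known", "first", "only" and "open" are said of these compounds alone.

Measured so far in an ADME assay on PBMC cells (Homo sapiens) for cytotoxicity (a higher number here means that more compound is tolerated, a lower number that less compound is tolerated), are three compounds:
- compound 1 `CC(CCNC(=O)c1c(Cl)cncc1Cl)N1CCC(C(Oc2ncccc2Cl)c2ccc(C(F)(F)F)cc2)CC1` gives 16700 nM
- compound 2 `CC(CCNC(=O)c1c(Cl)cncc1Cl)N1CCC(C(Oc2cccc(Cl)n2)c2ccc(C(F)(F)F)cc2)CC1` gives > 32500 nM
- compound 3 `CC(CCNC(=O)c1c(Cl)cncc1Cl)N1CCC(C(Oc2cccc(Cl)c2)c2ccc(C(F)(F)F)cc2)CC1` gives 8100 nM

Compound 2 stands at > 32500 nM, which is a limit of the assay and not a number.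

Compound 3 has the lowest number of the three, so it is the least tolerated. The unmeasured compound 4 `CC(CCNC(=O)c1c(Cl)cncc1Cl)N1CCC(C(Oc2ccccc2C#N)c2ccc(C(F)(F)F)cc2)CC1` has 2-cyanophenyl in place of 3-chlorophenyl on an oxygen on a saturated carbon. Among the compounds with values here, no measured step makes this exact swap and none brings in a nitrile. The closest guides change the same group on the same oxygen, and they are a 2.1-fold lower number from compound 1 to compound 3 (0.31 log units; beyond the scatter) and an at least 4.0-fold lower number from compound 2 to compound 3 (0.60 log units; beyond the scatter). Both lie beyond the scatter, and both end at compound 3 as the low point, so the other groups measured there gave higher numbers. The expected step in this assay is therefore small and upward, at a 1.5-fold higher number from compound 3 to compound 4 (0.17 log units; within the scatter), and it may not clear the scatter. For compound 4 the estimate is 12000 nM, with an expected range from 5500 nM to 27000 nM.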

Compound 4, half-maximal cytotoxic concentration: 17000 nM
Beside the measured number, compound 4's estimate is 1.4-fold (0.15 log units) below it, and the stated range covers the measured number.
By their numbers in this assay, from the lowest: compound 3; then compounds 1 and 4 (each within the scatter of the next). At a limit, above all of these: compound 2.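

The earlier compounds shown here left open whether a ring of carbon only on this oxygen always goes with the lowest number. Compound 4 also carries such a ring, yet 2-cyanophenyl in place of 3-chlorophenyl gives a 2.1-fold higher number from compound 3 to compound 4 (0.32 log units; beyond the scatter) in this assay, while 2-cyanophenyl in place of 3-chloropyridin-2-yl gives a 1.0-fold higher number from compound 1 to compound 4 (0.01 log units; within the scatter), so a ring nitrogen is not needed to reach the level of compound 1. 2-cyanophenyl in place of 6-chloropyridin-2-yl gives an at least 1.9-fold lower number from compound 2 to compound 4 (0.28 log units; that floor lies within the scatter). That step rests on compound 2, which stands at a limit and not at a number: the limit of > 32500 nM in this assay, at which 1 of the 4 values shown sits.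

This swap alters the substituent and its numbered place at once, so the compounds shown cannot say which of the two matters. On these data alone, how a plain phenyl ring, or a methoxy group or an amine on that ring, would compare remains open.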